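A few compounds are considered here, and "the series" means these few. Any claim that something is new, unique, unknown or untested is made for them only; others in the source may bear on it.

Three compounds of this series have been measured in a physicochemical assay for lipophilicity, in phosphate buffer, measured as octanol-water partition, with a stated time of 24 h; on this read-out lower numbers stand for lower lipophilicity and higher numbers for higher lipophilicity:

compound 1 `O=C(CN1C(=O)c2ccccc2C1=O)NN1C(=O)CSC1c1ccccc1`: 2.23
compound 2 `O=C(CN1C(=O)c2ccccc2C1=O)NN1C(=O)CSC1c1ccc(O)cc1`: 2.4
compound 3 `CN(C)c1ccc(C2SCC(=O)N2NC(=O)CN2C(=O)c3ccccc3C2=O)cc1`: 2.84

On these numbers compound 2 is the second highest of the three. Compound 1 lies closest to it, a number 0.17 log units higher from compound 1 to compound 2 (within the scatter), so the two cannot be told apart. Compound 3 lies furthest away, a number 0.44 log units higher from compound 2 to compound 3 (beyond the scatter). Among the compounds with values here, the only step that leaves out compound 2, a number 0.61 log units higher from compound 1 to compound 3 (beyond the scatter), is of the same modest kind.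

Compound 4 `O=C(CN1C(=O)c2ccccc2C1=O)NN1C(=O)CSC1c1cccs1` differs from compound 2 in one place: thiophen-2-yl in place of 4-hydroxyphenyl on a saturated ring carbon.

Within the data shown here, no measured step exchanges the whole aromatic ring on that saturated ring carbon; the steps so far only vary a single substituent on it. The most telling one is the step from compound 1 to compound 2, a number 0.17 log units higher from compound 1 to compound 2 (within the scatter), which shows that taking the hydroxy away or adding it hardly moves this read-out. Compound 4 loses the hydroxy and gives up one aromatic carbon in exchange for a ring sulfur, so the number is expected to settle close to the value of compound 1, a little under compound 2 at most. The expected step, a number 0.20 log units lower from compound 2 to compound 4 (within the scatter), is estimated to stay within the scatter. Compound 4 is therefore estimated at 2.2, in the range 1.8 to 2.6.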

Compound 4, partition coefficient: 2.15
Estimate against measurement, compound 4: 0.05 log units above; the measured number falls inside the stated range.
By their numbers in this assay, from the lowest: compounds 4, 1 and 2 (each within the scatter of the next); then compound 3.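

Across this assay, these results show that the whole aromatic ring on the saturated ring carbon can be exchanged, where the earlier compounds varied only a single substituent on it. Thiophen-2-yl in place of phenyl (a number 0.08 log units lower from compound 1 to compound 4 (within the scatter)) and in place of 4-hydroxyphenyl (a number 0.25 log units lower from compound 2 to compound 4 (within the scatter)) gives numbers that cannot be told apart, so on this read-out a five-membered aromatic ring with a sulfur is not distinguished from either of these six-membered rings, even though 4-hydroxyphenyl has a hydrogen-bond donor and thiophen-2-yl has none. The exchange does separate thiophen-2-yl from 4-(dimethylamino)phenyl (a number 0.69 log units lower from compound 3 to compound 4 (beyond the scatter)), which leaves compound 3 alone at the top of the four, though nothing given here accounts for any of these numbers.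

From the compounds shown here alone, all four compounds carry an aromatic ring on this carbon, so it remains open how the read-out would respond to a cyclohexyl ring, a longer alkyl chain or a pyridine ring in that place. Going by these compounds, it also remains open how a carboxylic acid or a primary amine on the aromatic ring would compare with hydroxy and dimethylamino, and the rest of the shared core stays the same throughout.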